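Hexyl for tert-butyl on the triazole of compound 2

The source may report more compounds than this note shows. Statements on the series, on what has been measured and on what is new or still open speak of the compounds shown alone.

Compound 1 `CC(O)c1cn(Cc2cc(=O)oc3cc(O)ccc23)nn1` and compound 2 `CC(C)(C)c1cn(Cc2cc(=O)oc3cc(O)ccc23)nn1` share one core. In a functional assay on HepG2 cells (Homo sapiens) for inhibition, read by MTT assay, with a stated time of 72 h (on this read-out higher numbers stand for weaker inhibition and lower numbers for stronger inhibition), compound 1 reaches only a limit, > 100000 nM. Compound 2 likewise reaches only a limit in this assay, > 100000 nM. The step that the two limits leave unreadable from compound 1 to compound 2 is therefore unreadable, both values sitting at the limit of > 100000 nM in this assay, at which 2 of the 2 values shown sit. Compound 3 `CCCCCCc1cn(Cc2cc(=O)oc3cc(O)ccc23)nn1` differs from compound 2 by hexyl in place of tert-butyl on an aromatic carbon. Going by the values given here, no measured step gives a readable size or direction for this change. Compound 3 is expected to give about 120000 nM, within 30000 nM to 500000 nM. The expected step is a step that the limit leaves unreadable from compound 2 to compound 3.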

Compound 3, half-maximal inhibitory concentration: 61600 nM
Compound 3: the middle estimate sits 1.9-fold (0.29 log units) above what was measured; the range from low to high includes it.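

Compound 3, with hexyl on the aromatic carbon, is the first compound shown to give a number rather than a limit in this assay. Compound 1 and compound 2 each give only a limit: the limit of > 100000 nM in this assay, at which 2 of the 3 values shown sit. The steps are floors only, an at least 1.6-fold lower number from compound 2 to compound 3 (0.21 log units; that floor lies within the scatter) and an at least 1.6-fold lower number from compound 1 to compound 3 (0.21 log units; that floor lies within the scatter), so the change is not shown to exceed the scatter.

On these data alone, their true sizes remain open. So does whether a longer chain than hexyl, or an amine at the end of the chain, would give a lower number.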